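The compounds below may be only part of what the source reports. "The series", "measured", "known", "first", "only" and "open" are said of these compounds alone.

Compound 1 `N#CC1=C(N)Oc2c(c3nc4ccccc4nc3c3ccccc23)C12C(=O)N(Cc1cnnn1-c1cc(Cl)ccc1Cl)c1ccccc12`: in a functional assay on HepG2 cells (Homo sapiens) for antiproliferative activity, read by MTT assay, with a stated time of 48 h (a lower number here means a stronger inhibitor, a higher number a weaker inhibitor), compound 1 gives > 50000 nM, which is a limit of the assay rather than a number.
Compound 2 `Cc1ccccc1-n1nncc1CN1C(=O)C2(C(C#N)=C(N)Oc3c(N)cc4nc5ccccc5nc4c32)c2ccccc21`: in this assay compound 2 gives > 50000 nM, again a limit rather than a number.

Compound 2 therefore stands at the edge of what this assay can report. Among the measured compounds shown here, its own value is a limit, and the one other value shown is a limit as well (the limit of > 50000 nM in this assay, at which 2 of the 2 values shown sit), so there is no measured number against which compound 2 could be ranked. Neither compound shows measurable inhibition of the growth of these liver cancer cells within the time of the test.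

Compound 3 `N#CC1=C(N)Oc2c(N)cc3nc4ccccc4nc3c2C12C(=O)N(Cc1cnnn1-c1ccccc1Cl)c1ccccc12` keeps the whole core of compound 2 and changes a single substituent (chloro in place of methyl on an aromatic carbon), chloro in place of methyl on an aromatic carbon. For the measured compounds named here, no step between two measured compounds is available to show what such a swap does here. Because both measured values sit at the limit (the limit of > 50000 nM in this assay, at which 2 of the 2 values shown sit), the step that the limit leaves unreadable from compound 2 to compound 3 is expected to stay within the scatter, in no particular direction. Compound 3 is accordingly estimated at 80000 nM, within a range from 30000 nM to 300000 nM, and most likely reported once more as a limit.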

Compound 3, half-maximal inhibitory concentration: 33500 nM
The estimate for compound 3 lay 2.4-fold (0.38 log units) above the measured number; the range from low to high includes it.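

In this assay compound 3 gives 33500 nM as the first true number among the compounds shown, so with a 2-chlorophenyl group in this place the shared core can be read by the test at all. Putting chloro in place of methyl on this ring gives an at least 1.4-fold lower number from compound 2 to compound 3 (0.17 log units; that floor lies within the scatter) as the only size that can be stated, which means these data do not establish a real difference between the two groups, although a larger one remains possible. As far as these compounds go, the true size of the step stays unknown because compound 2 has only a limit and not a number: the limit of > 50000 nM in this assay, at which 2 of the 3 values shown sit.

The compounds shown leave open whether the measurable value belongs to chloro in particular or would also appear with another small group on the same ring carbon, such as fluoro, bromo, methoxy or an amine. They also leave open how far a group such as a carboxylic acid or a longer chain in this place would move the number, in either direction, from the value of compound 3.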